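The source may report more compounds than this note shows. Statements on the series, on what has been measured and on what is new or still open speak of the compounds shown alone.

Compound 1 `CCS(=O)(=O)Nc1ccc(Oc2ccccc2)c(-c2cn(C)c(=O)c3[nH]ccc23)c1` and compound 2 `Cn1cc(-c2cc(C(N)=O)ccc2Oc2ccccc2)c2cc[nH]c2c1=O` share one core and differ at a single aromatic carbon. In an ADME assay on microsomes from liver (Rattus norvegicus) for metabolic stability, read by HPLC, using NADPH, with stated times of 5 min and 60 min, tested at 10 uM (a lower number here means slower removal, a higher number faster removal of the compound), compound 1 gives 3330 mL/min/kg, and in this assay compound 2 gives 550 mL/min/kg, the lower of the two numbers, set apart from compound 1 by a 6.1-fold lower number from compound 1 to compound 2 (0.78 log units; beyond the scatter). Compound 3 `Cn1cc(-c2cc(S(N)(=O)=O)ccc2Oc2ccccc2)c2cc[nH]c2c1=O` carries sulfamoyl in place of carbamoyl on an aromatic carbon. For the measured compounds named here, no measured step exchanges a carbamoyl for a sulfamoyl; the only step at hand put the carbamoyl in place of an (ethylsulfonyl)amino group and therefore bears on this change only indirectly. Because compound 2 already sits at 550 mL/min/kg and nothing measured points either way, compound 3 is expected to show no step beyond the scatter in this assay, a 1.1-fold lower number from compound 2 to compound 3 (0.04 log units; within the scatter). The estimate for compound 3 in this assay is accordingly 500 mL/min/kg, with a range from 200 mL/min/kg to 1300 mL/min/kg.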

Compound 3, clearance: 1320 mL/min/kg
The estimate for compound 3 lay 2.6-fold (0.42 log units) below the measured number, outside the stated range (above it).
By their numbers in this assay, from the lowest: compound 2; then compound 3; then compound 1.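

At the aromatic carbon para to a phenoxy group, this assay separates the two groups, with a 2.4-fold higher number from compound 2 to compound 3 (0.38 log units; beyond the scatter) on exchanging carbamoyl for sulfamoyl, so these groups, each with one hydrogen-bond donor and no net charge, do not give matching numbers here. The sulfamoyl also stands apart from the (ethylsulfonyl)amino group, with a 2.5-fold lower number from compound 1 to compound 3 (0.40 log units; beyond the scatter) on that exchange, which places compound 3 between the other two and shows that this one position gives three separate numbers. No measurement is at hand that accounts for this order.

The compounds shown leave open whether a carboxylic acid, an amine or a longer chain on the amide nitrogen at this position would give a number lower than that of compound 2. They also leave open whether the same order of the three groups would hold if another group replaced the phenoxy group.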